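The compounds below may be only part of what the source reports. "The series", "measured", "known", "first", "only" and "open" are said of these compounds alone.

Measured compounds:
Compound 1 `C=CCc1ccc(OCc2cn(-c3ccccc3CO)nn2)c(O)c1` — 52.1%
Compound 2 `C=CCc1cc(O)c(O)c(CN2CCC(CO)CC2)c1` — 38.6%
Compound 3 `C=CCc1cc(O)c(O)c(CN2CCC(CCO)CC2)c1` — 71.8%

In a functional assay on MIA PaCa-2 cells (Homo sapiens) for inhibition, read by MTT assay, with a stated time of 72 h, tested at 50 uM (on this read-out lower numbers stand for less inhibition of growth and higher numbers for more inhibition of growth at the one concentration tested), compound 1 gives 52.1%, which places it second highest of the three numbers shown. Its nearest neighbour is compound 2 with 38.6%, a value beyond the scatter below it, while compound 3 with 71.8% lies beyond the scatter above it.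

The step from compound 1 to compound 4 `C=CCc1ccc(OCc2cn(-c3cccc(C#N)c3)nn2)c(O)c1` changes the group on the aromatic nitrogen of the shared core: 3-cyanophenyl in place of 2-(hydroxymethyl)phenyl on an aromatic nitrogen

Among the compounds with values here, only one measured step is on record, a number 33.2 percentage points higher from compound 2 to compound 3 (beyond the scatter), and it concerns a different part of the molecule in a different pair, the two catechol-bearing compounds, where a hydroxymethyl replaced a hydroxy on a saturated chain. Within the data shown here, it does not speak to a swap of one aryl group for another on the aromatic nitrogen, so no measured step bears directly on the change from compound 1 to compound 4. With no guidance from the data, compound 4 is expected to sit near compound 1, a step of a number 2.1 percentage points lower from compound 1 to compound 4 (within the scatter) that is not expected to exceed the scatter.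

Compound 4 is therefore estimated at 50%, within a range from 30% to 70%.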

Compound 4, percent growth inhibition at one concentration: 41.6%
Beside the measured number, compound 4's estimate is 8.4 percentage points above it; the range from low to high includes it.
By their numbers in this assay, from the lowest: compounds 2 and 4 (each within the scatter of the next); then compound 1; then compound 3.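

In this assay, replacing 2-(hydroxymethyl)phenyl with 3-cyanophenyl on an aromatic nitrogen of the shared core gives a number 10.5 percentage points lower from compound 1 to compound 4 (beyond the scatter), the first sign that growth inhibition responds to the aryl group at this position, though the step is modest. The two groups match in heavy-atom count, and each holds one six-membered aromatic ring of carbon only, so the change is not one of size by that count; what differs is that the group leaving carries a hydrogen-bond donor and an oxygen, while the group entering carries a triple bond and a nitrogen. No measured evidence is available to explain the step, and this single pair cannot separate the loss of the hydroxymethyl from the gain of the nitrile.

The compounds shown leave open whether an unsubstituted phenyl on this nitrogen, or a phenyl bearing an amine or a carboxylic acid, would give a number nearer that of compound 1 or that of compound 4. They also leave open how this pair would compare at any concentration other than the single one tested.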